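Replacing Cyclohexyl with 2-Chlorophenyl in Compound 3

This account rests on a few compounds, and the source may have more. Where it says the series, first, only, none or still open, it means among the compounds named here.

Compound 3 `COc1ccc(C(=O)/C(=C/C2CCCCC2)CCOC(C)=O)cc1` stands at the edge of what is known: in a functional assay on A549 cells (Homo sapiens) for inhibition, read by XTT assay, with a stated time of 48 h (on this read-out higher numbers stand for weaker inhibition and lower numbers for stronger inhibition), compound 3 gives > 100000 nM, which is a limit of the assay and not a number (the limit of > 100000 nM in this assay, at which 1 of the 3 values shown sits). Compound 4 `COc1ccc(C(=O)/C(=C/c2ccccc2Cl)CCOC(C)=O)cc1` differs from compound 3 in one place: 2-chlorophenyl in place of cyclohexyl on a double-bonded chain carbon bound to a double-bonded chain carbon. Among the compounds with values here, one measured step touches this position, in the reverse direction: cyclohexyl entering for 2,4-dichlorophenyl gave an at least 1.4-fold higher number from compound 2 to compound 3 (0.15 log units; that floor lies within the scatter). Compound 2 `COc1ccc(C(=O)/C(=C/c2ccc(Cl)cc2Cl)CCOC(C)=O)cc1` gives 69200 nM in this assay. Compound 1 `COc1ccc(C(=O)/C(=C/c2ccccc2Cl)COC(=O)c2ccccc2)cc1`, carrying the same 2-chlorophenyl on a different chain, gives 20100 nM. Compound 4 is therefore expected to yield a measurable number, with a step of an at least 2.0-fold lower number from compound 3 to compound 4 (0.30 log units; that floor lies within the scatter) toward stronger inhibition. Compound 4 is estimated at 50000 nM, between 15000 nM and 150000 nM.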

Compound 4, half-maximal inhibitory concentration: > 100000 nM
Compound 4 was reported as a limit; the forecaster's own chance of this, stated with the estimate: 25%; middle value at least 2.0-fold (0.30 log units) away from the limit.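

Compound 3 and compound 4 both rest at a limit of this assay, so the step between them cannot be read, and 2-chlorophenyl in place of cyclohexyl brought no measurable number: the limit of > 100000 nM in this assay, at which 2 of the 4 values shown sit.

Hydrogen in place of chloro on an aromatic carbon gave an at least 1.4-fold higher number from compound 2 to compound 4 (0.15 log units; that floor lies within the scatter). Within the data shown here, with 2-chlorophenyl held fixed, acetoxymethyl in place of benzoyloxy gave an at least 4.9-fold higher number from compound 1 to compound 4 (0.69 log units; beyond the scatter), so the one step beyond the scatter lies in the chain and not in the ring.

On these data alone, whether an amine or a carboxylic acid in place of the acetoxymethyl would bring a measurable number remains open.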